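This account rests on a few compounds, and the source may have more. Where it says the series, first, only, none or still open, it means among the compounds named here.

Compound 1 `Nc1ccc(-c2ccc(NC3=CC(=O)c4ncncc4C3=O)cc2)cc1` is one of three entries with a result in a functional assay on MIA PaCa-2 cells (Homo sapiens) for cytotoxicity, read by MTT assay, with a stated time of 72 h; on this read-out higher numbers stand for weaker inhibition and lower numbers for stronger inhibition; there compound 1 gives 2500 nM, which is the higher of the two numbers recorded. The nearest neighbour is compound 2 `O=C1C(NCc2ccc(F)cc2)=CC(=O)c2ncncc21`, which in this assay gives 1700 nM; the gap to compound 1 lies within the scatter, so the two are read as equivalent. Compound 3 `O=C1C(Nc2cccc(B(O)O)c2)=CC(=O)c2ncncc21` reaches only a limit in this assay, reported as > 10000 nM; this is the one case of the limit of > 10000 nM in this assay, at which 1 of the 3 values shown sits, in the set.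

Compound 4 `CCOC(=O)c1ccc(NC2=CC(=O)c3ncncc3C2=O)cc1` is not yet measured. Relative to compound 1 the change is ethoxycarbonyl in place of 4-aminophenyl on an aromatic carbon. Going by the values given here, no measured pair in the set shares this kind of change, so the expectation rests on the spread seen across compounds 1 to 3 alone. For compound 4 a small shift, if any, toward a higher number in this assay is expected, with the step of a 1.3-fold higher number from compound 1 to compound 4 (0.11 log units; within the scatter) most likely inside the scatter. Compound 4 is thus estimated at 3200 nM, within 1100 nM to 10000 nM.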

Compound 4, half-maximal inhibitory concentration: 5500 nM
Compound 4: the middle estimate sits 1.7-fold (0.24 log units) below what was measured; low and high end bracket the measured number.
By their numbers in this assay, from the lowest: compounds 2 and 1 (each within the scatter of the next); then compound 4. At a limit, above all of these: compound 3.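

In this assay, going by these compounds alone, ethoxycarbonyl in place of 4-aminophenyl on an aromatic carbon, para to a large group, gives a 2.2-fold higher number from compound 1 to compound 4 (0.34 log units; beyond the scatter), the first step that can be read across a single change. This position therefore keeps a measured number without the 4-aminophenyl group and its six-membered aromatic ring, though the exchange for a group with no ring moves the number modestly and beyond the scatter. No data shown here bear on what lies behind this step.

Within the data shown here, the single step exchanges the whole group, leaving open whether the shift follows the loss of 4-aminophenyl or the arrival of ethoxycarbonyl. How a carboxylic acid, a primary amide or an unsubstituted phenyl at this place would compare remains an open question.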